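A Methoxy Step Repeated on a Second Core

The source may hold more compounds than are shown below. What is called first, only, known or untested is meant among the compounds shown, and "the series" means these compounds.

Compound 1 `COc1ccc(C(=O)/C=C\Nc2ccc(-c3nc4cc(OC)c(OC)c(OC)c4s3)cc2C)cc1F` and compound 3 `COc1cc(OC)c2sc(-c3ccc(N/C=C\C(=O)c4ccc(OC)c(F)c4)c(C)c3)nc2c1` share a core and differ in a single place: methoxy in place of hydrogen on an aromatic carbon. In a functional assay on MIA PaCa-2 cells (Homo sapiens) for antiproliferative activity, read by sulforhodamine B assay, with a stated time of 48 h (a lower number here means a stronger inhibitor, a higher number a weaker inhibitor), compound 3 gives 16300 nM, while compound 1 gives 1800 nM, so that a 9.1-fold lower number from compound 3 to compound 1 (0.96 log units; beyond the scatter).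

Compound 2 `COc1cc(OC)c2sc(-c3ccc(N/C=C\C(=O)c4cc(OC)c(OC)c(OC)c4Br)c(C)c3)nc2c1` in this assay gives 16000 nM; this value and that of compound 3 lie within the scatter of each other, so no order between them can be read. The difference between the core of compound 2 and the core of compound 3 is not broken down here.

Compound 4 `COc1cc(C(=O)/C=C\Nc2ccc(-c3nc4cc(OC)c(OC)c(OC)c4s3)cc2C)c(Br)c(OC)c1OC` stands to compound 2 as compound 1 stands to compound 3: methoxy in place of hydrogen on an aromatic carbon. The surroundings of the place are described in the same words for both pairs, so this is the same change on a different core.

Going by the values given here, the step is expected to be an 8.0-fold lower number from compound 2 to compound 4 (0.90 log units; beyond the scatter), beside the earlier one, because a 9.1-fold lower number from compound 3 to compound 1 (0.96 log units; beyond the scatter) is the only measured example of this change and nothing among the three compounds speaks against carrying it over. Compound 4 is accordingly estimated at 2000 nM, with an expected range from 700 nM to 6000 nM.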

Compound 4, half-maximal inhibitory concentration: 24300 nM
For compound 4 the middle estimate is 12-fold (1.08 log units) below the measured one; measured number above the stated range.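

In this assay, adding the methoxy group gives a 1.5-fold higher number from compound 2 to compound 4 (0.18 log units; within the scatter), so on this core the change produces no readable shift. Set against the step on the other core, the same change does not carry over: the same change on two cores in this assay, a 9.1-fold lower number (0.96 log units; beyond the scatter) from compound 3 to compound 1 and a 1.5-fold higher number (0.18 log units; within the scatter) from compound 2 to compound 4, 14-fold (1.14 log units) apart, beyond the scatter of two such steps This shows that, within this series, the clear gain seen on one core cannot be assumed on another, even when the surroundings of the changed place are described in the same words; it does not show what separates the two outcomes, and with one pair per core it gives no general rule for either core.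

The compounds shown leave open which of the differences between the two cores decides the outcome, as no pair here isolates any one of them. They also leave open whether an ethoxy group or an amine at the same place would follow the step seen on one core, the other, or neither.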